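Swapping the Fluorophenyl for an Oxazolyl on the Amide

A few compounds are considered here, and "the series" means these few. Any claim that something is new, unique, unknown or untested is made for them only; others in the source may bear on it.

Compound 1, `O=C(C1CCCC1)N1CCCn2nc(COc3ccccc3)cc21`: 41%
Compound 2, `O=C(c1cccc(F)c1)N1CCCn2nc(COc3ccccc3)cc21`: 61%

Both compounds were tested in a functional assay on HEK293 cells for positive allosteric modulation of metabotropic glutamate receptor 5 (Homo sapiens), read by calcium flux; on this read-out higher numbers stand for larger maximal responses and lower numbers for smaller maximal responses. Compound 1 gives 41% in this assay, and compound 2 gives 61%. Going by the values given here, of the two numbers, compound 2 stands highest, with compound 1 as its only neighbour a step below.

Among the compounds with values here, the only measured step is a number 20 percentage points higher from compound 1 to compound 2 (beyond the scatter), where 3-fluorophenyl replaced cyclopentyl on a carbonyl carbon. It shows that exchanging the group on this carbonyl carbon can move the maximal response beyond the scatter.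

Compound 3, `O=C(c1ccno1)N1CCCn2nc(COc3ccccc3)cc21`, differs from compound 2 in one place: 1,2-oxazol-5-yl in place of 3-fluorophenyl on a carbonyl carbon. Within the data shown here, no measured step covers an exchange of one aromatic ring for another on this carbonyl carbon, so the direction rests on thin ground. Among the measured compounds shown here, because the one known step, a number 20 percentage points higher from compound 1 to compound 2 (beyond the scatter), was modest, a step of similar or smaller size is plausible here, and a small drop is expected, a number 11 percentage points lower from compound 2 to compound 3 (beyond the scatter). Compound 3 is therefore estimated at 50%, in a range from 25% to 75%.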

Compound 3, largest response reached (reported as percent of maximum), in percent of the reference or control that the assay uses: 22%
Beside the measured number, compound 3's estimate is 28 percentage points above it; the measured number lies below the stated range.
By their numbers in this assay, from the lowest: compound 3; then compound 1; then compound 2.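

In this assay the exchange of 3-fluorophenyl for 1,2-oxazol-5-yl on the carbonyl carbon gives a number 39 percentage points lower from compound 2 to compound 3 (beyond the scatter) and this large step shows that one aromatic ring cannot simply stand in for another at this position. The exchange of cyclopentyl for 1,2-oxazol-5-yl gives a number 19 percentage points lower from compound 1 to compound 3 (beyond the scatter) so the three groups do not sort into aromatic rings above and cyclopentyl below, since cyclopentyl falls in the middle of the two aromatic groups. The entering ring is five-membered with 2 hetero atoms and 2 hydrogen-bond acceptors, where 3-fluorophenyl has a six-membered ring of carbon only and 0 acceptors, yet no measurement available here connects the drop to any one of these differences.

The compounds shown leave open whether the fall follows the ring size, the hetero atoms or the loss of the fluorine. A plain phenyl on the same carbonyl carbon would show what the fluorine contributes, and a pyridine or thiophene ring would help separate the effect of hetero atoms from that of ring size.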